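The source may report more compounds than this note shows. Statements on the series, on what has been measured and on what is new or still open speak of the compounds shown alone.

The measured compounds:
Compound 1 `COc1cc(OC)c(OC)cc1/C=C/C(=O)c1ccc(OC)c2c1OC(C)(C)C=C2`: in a functional assay on HCT-116 cells (Homo sapiens) for antiproliferative activity, read by MTT assay, with a stated time of 24 h (on this read-out higher numbers stand for weaker inhibition and lower numbers for stronger inhibition), compound 1 gives > 10000 nM, a limit of the assay and not a number.
Compound 2 `COc1ccc(C(=O)/C=C/c2ccc(Br)cc2)c2c1C=CC(C)(C)O2`: compound 2 gives > 10000 nM, again only a limit.
Compound 3 `COc1ccc(C(=O)/C=C/c2ccc(-c3ccccc3)cc2)c2c1C=CC(C)(C)O2`: compound 3 gives > 10000 nM, also a limit.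

Compound 2 thus stands at the limit of this assay, and no number places it relative to the others. Among the compounds with values here, the only measured step, a step that the two limits leave unreadable from compound 2 to compound 3, could not be read, with both of its ends at a limit. Compound 4 `COc1ccccc1/C=C/C(=O)c1ccc(OC)c2c1OC(C)(C)C=C2` differs from compound 2 by 2-methoxyphenyl in place of 4-bromophenyl on a double-bonded chain carbon bound to a double-bonded chain carbon. Within the data shown here, no measured step bears on this change. The one pointer is the limit of > 10000 nM in this assay, at which 3 of the 3 values shown sit. Given (the limit of > 10000 nM in this assay, at which 3 of the 3 values shown sit), the step from compound 2 to compound 4 is expected to be a step that the limit leaves unreadable from compound 2 to compound 4, with no readable direction. Compound 4 is estimated at 15000 nM, within 4000 nM to 60000 nM, most probably reported once more as a limit.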

Compound 4, half-maximal inhibitory concentration: > 10000 nM
Compound 4 ended at the assay's limit (the forecaster's own chance of this, stated with the estimate: 80%); the middle value lies beyond the limit too.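

Compound 2 and compound 4 both stand only as limits, so the step between them cannot be read. The compounds shown leave open whether any change to the shared core gives a readable value in this assay.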